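From Thiophen-3-yl to Phenyl: A Step Expected to Be Small

This account rests on a few compounds, and the source may have more. Where it says the series, first, only, none or still open, it means among the compounds named here.

Of the compounds shown here, three built on one shared core have been tested in a functional assay on HCT-15 cells (Homo sapiens) for cytotoxicity, read by CCK-8 assay and cell counting, with a stated time of 2 days; on this read-out higher numbers stand for weaker inhibition and lower numbers for stronger inhibition. Compound 1 `Oc1cccc(-c2cc(-c3ccc(Cl)cc3)nc(-c3ccco3)c2)c1` gives 10200 nM. Compound 2 `Oc1cccc(-c2cc(-c3ccc(Cl)cc3)nc(-c3ccsc3)c2)c1` gives 8850 nM, and compound 3 `Oc1cccc(-c2cc(-c3ccsc3)nc(-c3ccccc3Cl)c2)c1` gives 2500 nM. Compound 2 thus carries the second highest number of the three: it stands close to compound 1 and clearly apart from compound 3.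

Two single-point changes link these numbers. Putting thiophen-3-yl in place of furan-2-yl gave a 1.2-fold lower number from compound 1 to compound 2 (0.06 log units; within the scatter), whereas putting 2-chlorophenyl in place of 4-chlorophenyl gave a 3.5-fold lower number from compound 2 to compound 3 (0.55 log units; beyond the scatter).

Compound 4 `Oc1cccc(-c2cc(-c3ccccc3)nc(-c3ccc(Cl)cc3)c2)c1` differs from compound 2 in one place: phenyl in place of thiophen-3-yl on an aromatic carbon. Among the measured compounds shown here, the only measured step at this same place is the one from compound 1 to compound 2, a swap of one small aromatic ring for another, and it stayed within the scatter. The step from compound 2 to compound 3 concerns a different group and does not speak to this change. For the measured compounds named here, no measured compound carries a phenyl at this place, so the expectation rests on a single comparison: a step no larger than the scatter is expected, a 1.1-fold lower number from compound 2 to compound 4 (0.04 log units; within the scatter). Compound 4 is therefore estimated at 8000 nM, within a range from 3500 nM to 18000 nM.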

Compound 4, half-maximal inhibitory concentration: 8110 nM
Beside the measured number, compound 4's estimate is 1.0-fold (0.01 log units) below it; measured number inside the range.
By their numbers in this assay, from the lowest: compound 3; then compounds 4, 2 and 1 (each within the scatter of the next).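

Among the compounds shown here, compound 4 is the first at this place to carry a six-membered aromatic ring of carbon only, and in this assay the swap gives a 1.1-fold lower number from compound 2 to compound 4 (0.04 log units; within the scatter). The comparison with the furan-2-yl compound, a 1.3-fold lower number from compound 1 to compound 4 (0.10 log units; within the scatter), also stays within the scatter, so furan-2-yl, thiophen-3-yl and phenyl cannot be told apart here when a 4-chlorophenyl group and a 3-hydroxyphenyl group are also present on the shared core; neither the step from a five-membered to a six-membered ring nor the loss of the sulfur atom and the hydrogen-bond acceptor counted for thiophen-3-yl moves the number beyond the scatter. Nothing on hand explains why these three aromatic groups give such similar numbers.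

From the compounds shown here alone, all three groups at this place are aromatic rings, so it remains open whether an amine, a carboxylic acid or a longer chain such as n-butyl would give a similar number. Going by these compounds, it is also open whether phenyl and thiophen-3-yl would still match when a 2-chlorophenyl group, as in compound 3, replaces the 4-chlorophenyl group.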